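The compounds below may be only part of what the source reports. "The series", "measured", "known", "first", "only" and "open" are said of these compounds alone.

Measured compounds:
compound 1, `O=C(O)CCCOc1ccc(-c2cc(Oc3cccnc3)ccc2Cl)cc1`, > 9950 nM in a functional assay on isolated protein for agonist activity at Free fatty acid receptor 1 (Homo sapiens), read by HTRF and inositol phosphate accumulation, with a stated time of 60 min; on this read-out lower numbers stand for an effect already at smaller amounts and higher numbers for an effect only at larger amounts of compound
compound 2, `Cc1cc(OC2CCC2)cc(-c2ccc3oc(CCC(=O)O)cc3c2)c1`, 2960 nM in this assay

The value of compound 1 in this assay is a limit of the assay, not a number. Among the measured compounds shown here, compound 2 is therefore the only compound with a numerical result; of the two values shown, one sits at the limit of > 9950 nM in this assay, at which 1 of the 2 values shown sits, so compound 2 stands alone as the reference point for this assay.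

Compound 3, `O=C(O)CCc1cc2cc(-c3cccc(OC4CCC4)c3)ccc2o1`, has not yet been measured. It differs from compound 2 by hydrogen in place of methyl on an aromatic carbon. For the measured compounds named here, no measured pair shows this change, so the size of the step is open. The loss of one carbon on an aromatic carbon is expected to cost a little potency, but the step from a 1.5-fold higher number from compound 2 to compound 3 (0.18 log units; within the scatter) is estimated to stay close to the usual scatter. Compound 3 is expected to give 4500 nM, between 1500 nM and 14000 nM.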

Compound 3, half-maximal effective concentration: 2500 nM
Compound 3: the middle estimate sits 1.8-fold (0.26 log units) above what was measured; the range from low to high includes it.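

Placing hydrogen in place of methyl on this aromatic carbon, meta to a cyclobutyloxy group, gives in this assay a 1.2-fold lower number from compound 2 to compound 3 (0.07 log units; within the scatter). Among the compounds shown here, the first measured step at this position therefore shows that the two compounds cannot be told apart in this read-out, and that the methyl group is not required for the activity seen in compound 2. Nothing shown gives a reason for this outcome.

The compounds shown leave open whether a different group on this carbon, such as chlorine, methoxy or trifluoromethyl, would give a step beyond the scatter. They also leave open whether the same exchange of methyl for hydrogen would be as small with a longer chain carrying the carboxylic acid.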